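Trimming a Branched Side Chain: From Compound 2 to Compound 4

This account rests on a few compounds, and the source may have more. Where it says the series, first, only, none or still open, it means among the compounds named here.

Compound 1, `C[C@@H](Nc1nc(Cl)nc(NC(C)(C)C)n1)c1ccccc1`, in an ADME assay on the whole organism for inhibition, with Oryza sativa as the target, with a stated time of 4 days; on this read-out higher numbers stand for weaker inhibition and lower numbers for stronger inhibition: 9330 nM
Compound 2, `CC[C@@H](C)Nc1nc(Cl)nc(N[C@@H](C)c2ccccc2)n1`, in this assay: 9770 nM
Compound 3, `CNc1nc(Cl)nc(N[C@H](C)c2ccccc2)n1`, in this assay: 22400 nM

Among these three values compound 2 stands second highest. Its number sits close to that of compound 1, within the usual scatter, while compound 3 lies beyond the scatter above it.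

Compound 4, `CCCNc1nc(Cl)nc(N[C@@H](C)c2ccccc2)n1`, has not yet been measured. It differs from compound 2 by hydrogen in place of methyl on a saturated chain carbon bound to a nitrogen on an aromatic ring and a saturated chain carbon.

For the measured compounds named here, one measured step bears on this change: a 2.4-fold higher number from compound 1 to compound 3 (0.38 log units; beyond the scatter). There, a larger group on a nitrogen on an aromatic ring gave way to a smaller one, and the number went up modestly. The change from compound 2 to compound 4 points the same way, sec-butyl to propyl, but removes less than that step did. An increase of the same sign but smaller size is therefore expected, perhaps not clearly beyond the scatter.

Compound 4 is expected to give 13000 nM in this assay, with a range from 7000 nM to 25000 nM. The expected shift is a 1.3-fold higher number from compound 2 to compound 4 (0.12 log units; within the scatter).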

Compound 4, half-maximal inhibitory concentration: 32400 nM
Estimate against measurement, compound 4: 2.5-fold (0.40 log units) below, outside the stated range (above it).
By their numbers in this assay, from the lowest: compounds 1 and 2 (each within the scatter of the next); then compounds 3 and 4 (each within the scatter of the next).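

In this assay, the methyl on this saturated chain carbon turns out to matter: going from sec-butyl to propyl gives a 3.3-fold higher number from compound 2 to compound 4 (0.52 log units; beyond the scatter) and so loss of that one carbon is enough to carry the number beyond the scatter. The earlier step, a 2.4-fold higher number from compound 1 to compound 3 (0.38 log units; beyond the scatter) and took tert-butyl down to methyl, a much bigger change to the group on a nitrogen on an aromatic ring that also lies beyond the scatter, so among these compounds the number does not simply follow how much of the group is removed. Nothing available gives a reason for the effect of this methyl.

The compounds shown leave open whether the branch itself counts or only the shape of the whole chain, a question that groups such as isopropyl, cyclobutyl or a longer straight chain like butyl in the same place could help to answer. They also leave open whether the mirror-image arrangement at the branched carbon of the sec-butyl group would give a number like that of compound 2 or one closer to that of compound 4.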